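This account rests on a few compounds, and the source may have more. Where it says the series, first, only, none or still open, it means among the compounds named here.

Measured so far in a functional assay on KB cells (Homo sapiens) for cytotoxicity, read by MTT assay, with a stated time of 72 h; on this read-out lower numbers stand for an effect already at smaller amounts and higher numbers for an effect only at larger amounts of compound:
compound 1, `O=C1/C(=C\c2ccc(O)cc2)c2ccccc2N1c1c(Cl)cccc1Cl`: 2 ug/mL
compound 2, `Cc1ccc2nc(Cl)c(/C=C3\C(=O)N(c4c(Cl)cccc4Cl)c4ccccc43)cc2c1`: 100 ug/mL
compound 3, `CN(C)c1ccc(/C=C2\C(=O)N(c3c(Cl)cccc3Cl)c3ccccc32)cc1`: 15 ug/mL

Compound 3 stands second highest of the three numbers in this assay. Its nearest neighbour is compound 2, whose value is the higher of the two; the furthest is compound 1, whose value is the lower. All three share the same core and differ only in the aryl group hanging from the double-bonded chain carbon.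

Compound 4, `O=C1/C(=C\c2cccc(Cl)c2)c2ccccc2N1c1c(Cl)cccc1Cl`, has not yet been measured in this assay. It differs from compound 3 in one place: 3-chlorophenyl in place of 4-(dimethylamino)phenyl on a double-bonded chain carbon bound to a double-bonded ring carbon.

Within the data shown here, only one measured step concerns this position, a 7.5-fold higher number from compound 1 to compound 3 (0.88 log units; beyond the scatter), and it shows that exchanging a substituent on that aryl ring can move the number well beyond the scatter. Among the measured compounds shown here, no measured pair, however, exchanges the whole aryl group for a chlorophenyl, so the direction of the present change is not fixed by the data. Compound 2, with its larger chlorine-bearing ring, gives the highest number of the three, while compound 1 gives the lowest; compound 4 is expected to fall between these, close to compound 3, with the step of a 1.3-fold higher number from compound 3 to compound 4 (0.12 log units; within the scatter) expected to stay within the scatter. The estimate for compound 4 in this assay is 20 ug/mL, with a range from 5 ug/mL to 80 ug/mL.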

Compound 4, concentration for half-maximal effect: 2 ug/mL
Compound 4: middle estimate off by 10-fold (1.00 log units), on the high side, and the stated range ends above it.
By their numbers in this assay, from the lowest: compounds 1 and 4 (each within the scatter of the next); then compound 3; then compound 2.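

In this assay, among these compounds, 3-chlorophenyl in place of 4-(dimethylamino)phenyl on the double-bonded chain carbon gives a 7.5-fold lower number from compound 3 to compound 4 (0.88 log units; beyond the scatter), the first measured step at this position that replaces the whole aryl group and lowers the number. Read with no change at the digits printed from compound 1 to compound 4 (within the scatter), it shows that 4-hydroxyphenyl and 3-chlorophenyl stand level at this position even though they carry different substituents at different ring positions, while 4-(dimethylamino)phenyl stands apart from both, so among these three groups the higher number belongs to 4-(dimethylamino)phenyl alone. Nothing available gives a reason for this difference.

The compounds shown leave open whether the chlorine's place on the ring matters, since 4-chlorophenyl does not appear among them, and whether unsubstituted phenyl would stand level with 3-chlorophenyl and 4-hydroxyphenyl. They also leave open whether the higher number seen with the dimethylamino group extends to other amines on the ring, such as a primary amine or a morpholine, or whether it is particular to that one group.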